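A few compounds are considered here, and "the series" means these few. Any claim that something is new, unique, unknown or untested is made for them only; others in the source may bear on it.

Compound 1 `O=C(NCc1ccc(CNS(=O)(=O)c2cccc(Cl)c2)cc1)c1ccc(F)cc1`: 20%
Compound 2 `O=C(NCc1ccc(CNS(=O)(=O)c2ccc(CN3CCCC3)cc2)cc1)c1ccc(F)cc1`: 20%

Of the compounds shown here, two have been measured in a functional assay on the whole organism (strain C57BL/6J) for inhibition, with Mus musculus as the target, read by mobility shift assay and paw edema, with stated times of 30 min, 74 h and 2 h, at a dose of 10 mg/kg by the intraperitoneal route; a lower number here means less inhibition, a higher number more inhibition at the dose given (going by the name of the read-out). Compound 1 gives 20%, and compound 2 gives 20%. At the digits reported the two stand level, within the usual scatter of repeated measurements of this kind, so neither number can be called higher or lower than the other. Among the compounds with values here, no pair of measured compounds differs in one place only, so no single step between measured compounds can be drawn; the data show only that compound 1 and compound 2 give the same read-out.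

Compound 3 `O=C(NCc1ccc(CNS(=O)(=O)c2ccc3c(c2)CCO3)cc1)c1ccc(F)cc1` has not yet been measured. It differs from compound 1 in one place: a group of 9 heavy atoms (8 carbon, 1 oxygen; one five-membered non-aromatic ring with 1 hetero atom, one six-membered aromatic ring of carbon only) in place of a group of 7 heavy atoms (6 carbon, 1 chlorine; one six-membered aromatic ring of carbon only), on a sulfonyl sulfur. The two measured values do not show whether a change on the sulfonyl sulfur moves the read-out: compound 1 and compound 2, which carry different groups there, give the same number. The step of no change at the digits printed from compound 1 to compound 3 (within the scatter) is therefore expected to lie within the scatter. The estimate for compound 3 in this assay is 20%, with a range from 5% to 40%.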

Compound 3, a percentage reported as inhibition, in the whole organism at one dose (the size of the read-out at that dose, not a potency): 43%
Beside the measured number, compound 3's estimate is 23 percentage points below it, outside the stated range (above it).
By their numbers in this assay, from the lowest: compounds 1 and 2 (each within the scatter of the next); then compound 3.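

In this assay the sulfonyl sulfur proves to be a place where the read-out can move: exchanging the 3-chlorophenyl group for the group of 9 heavy atoms, with its five-membered non-aromatic ring holding 1 hetero atom, gives a number 23 percentage points higher from compound 1 to compound 3 (beyond the scatter) at the dose used. The earlier compounds shown here could not show this, as they differ in more than one place and their level numbers say nothing about a single change on that sulfur. No measurement shown bears on what lies behind this step, which remains a single observation of the size of the read-out at one dose and not a potency.

The compounds shown leave open whether the step follows from the oxygen of the new ring or from the ring as a whole, a question that a methoxyphenyl group on the sulfonyl sulfur, or the same ring system with carbon in place of that oxygen, would begin to address. They also leave open how a carboxylic acid or an amine carried on the ring attached to the sulfonyl sulfur would compare with the group in compound 3.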